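Chloro for methyl on the phenol ring of compound 1

The source may hold more compounds than are shown below. What is called first, only, known or untested is meant among the compounds shown, and "the series" means these compounds.

Measured compounds:
- compound 1, `Cc1cc(CNC(C)(C)C)c(O)c(Nc2nc3cc(F)c(F)cc3n2Cc2ccc(C(F)(F)F)cc2)c1`: 10000 nM
- compound 2, `CCN(CC)Cc1ccc(Nc2nc3ccccc3n2Cc2ccc(F)cc2)cc1O`: 45800 nM
- compound 3, `Cc1cc(CNC(C)(C)C)c(O)c(Nc2nc3cc(F)c(F)cc3[nH]2)c1`: 16700 nM

The assay is an ADME assay on CHO cells (Cricetulus griseus) for inhibition, read by MTT assay; a higher number here means a weaker inhibitor, a lower number a stronger inhibitor. Of the three numbers, compound 1 gives the lowest, at 10000 nM; compound 3 stands nearest, and the step of a 1.7-fold higher number from compound 1 to compound 3 (0.22 log units; within the scatter) lies within the scatter, so no order between compound 1 and compound 3 can be read from it. Compound 2, with its value of 45800 nM, stands furthest from compound 1, a gap beyond the scatter.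

Compound 4, `CC(C)(C)NCc1cc(Cl)cc(Nc2nc3cc(F)c(F)cc3n2Cc2ccc(C(F)(F)F)cc2)c1O`, differs from compound 1 in one place: chloro in place of methyl on an aromatic carbon. Among the measured compounds shown here, no measured pair shows this change. For the measured compounds named here, the one measured step, a 1.7-fold higher number from compound 1 to compound 3 (0.22 log units; within the scatter), concerns a different place on the core of compound 1 and was within the scatter; it says nothing about a chloro in place of methyl. Going by the values given here, with no step that bears on the change, the step of no change at the digits printed from compound 1 to compound 4 (within the scatter) is expected to stay within the scatter, in no particular direction. Compound 4 is therefore estimated at 10000 nM, with a range from 4000 nM to 25000 nM.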

Compound 4, half-maximal inhibitory concentration in the CHO assay: > 50000 nM
Compound 4 gave a limit, no number (the forecaster's own chance of this, stated with the estimate: 10%); at least 5.0-fold (0.69 log units) between middle value and limit.
By their numbers in the CHO assay, from the lowest: compounds 1 and 3 (each within the scatter of the next); then compound 2. At a limit, above all of these: compound 4.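

Among the compounds shown here, in the CHO assay, the result gives the first reading at this position of the core of compound 1: chloro in place of methyl, para to the hydroxy group, gives an at least 5.0-fold higher number from compound 1 to compound 4 (0.69 log units; beyond the scatter), so compound 4 is a weaker inhibitor, and the value of compound 4 is a limit of the assay, not a number: the limit of > 50000 nM in the CHO assay, at which 1 of the 4 values shown sits. In a physicochemical assay for solubility, read by HPLC, measured as kinetic solubility, with a stated time of 24 h, at pH 6.5 (a higher number here means a more soluble compound, a lower number a less soluble compound), compound 1 gives < 5000 nM, which is a limit and not a number. In the physicochemical assay compound 4 gives < 5000 nM, also a limit and not a number, and the step between the two cannot be read: the limit of < 5000 nM in the physicochemical assay, at which 2 of the 2 values shown sit.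

The compounds shown leave open how large the step in the CHO assay really is, and whether it belongs to chloro itself or would also appear with another group on this aromatic carbon, such as fluoro, methoxy or a nitrile. They also leave open whether the same change would give a step of this kind on compound 3, which carries hydrogen in place of 4-(trifluoromethyl)benzyl on an aromatic nitrogen.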